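This account rests on a few compounds, and the source may have more. Where it says the series, first, only, none or still open, it means among the compounds named here.

Measured compounds:
compound 1 `Cc1nc2c3ccccc3ccc2c2nc3c(ccc4ccccc43)c(-c3cccnc3)c12` gives 34200 nM in a functional assay on HCT-116 cells (Homo sapiens) for cytotoxicity, read by MTT assay, with a stated time of 48 h; a lower number here means a stronger inhibitor, a higher number a weaker inhibitor;
compound 2 `Cc1nc2c3ccccc3ccc2c2nc3c(ccc4ccccc43)c(-c3cc([N+](=O)[O-])ccc3N)c12` gives 6010 nM;
compound 3 `Cc1nc2c3ccccc3ccc2c2nc3c(ccc4ccccc43)c(-c3ccc(O)cc3)c12` gives 3190 nM.

Among these three, compound 2 stands second highest. Its nearest neighbour is compound 3, a step described as a 1.9-fold lower number from compound 2 to compound 3 (0.28 log units; within the scatter), so the two cannot be told apart. Its furthest is compound 1, from which the step of a 5.7-fold lower number from compound 1 to compound 2 (0.76 log units; beyond the scatter) lies beyond the scatter.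

Compound 4 `Cc1ccc(-c2c3ccc4ccccc4c3nc3c2c(C)nc2c4ccccc4ccc32)cc1` differs from compound 2 in one place: 4-methylphenyl in place of 2-amino-5-nitrophenyl on an aromatic carbon. All three measured steps change the same aryl group on the shared core, so all bear on this change. Two were clear: a 5.7-fold lower number from compound 1 to compound 2 (0.76 log units; beyond the scatter) and an 11-fold lower number from compound 1 to compound 3 (1.03 log units; beyond the scatter), both away from the pyridin-3-yl compound. The third, a 1.9-fold lower number from compound 2 to compound 3 (0.28 log units; within the scatter), was not clear. Nothing measured yet carries a group with neither donors nor acceptors, so the step to 4-methylphenyl is unguided; a step of either direction, or none beyond the scatter, is possible, and the expected step is a 1.1-fold lower number from compound 2 to compound 4 (0.04 log units; within the scatter). The estimate for compound 4 is therefore 5500 nM, with a range from 1500 nM to 20000 nM.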

Compound 4, half-maximal inhibitory concentration: 67000 nM
Compound 4: the middle estimate sits 12-fold (1.09 log units) below what was measured; measured number outside the range, above it.
By their numbers in this assay, from the lowest: compounds 3 and 2 (each within the scatter of the next); then compounds 1 and 4 (each within the scatter of the next).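

In this assay, a plain 4-methylphenyl group at this position does not behave like the other two benzene-ring groups: the swap for 2-amino-5-nitrophenyl gives an 11-fold higher number from compound 2 to compound 4 (1.05 log units; beyond the scatter), and the single change on the ring from hydroxy to methyl gives a 21-fold higher number from compound 3 to compound 4 (1.32 log units; beyond the scatter), the largest step among these compounds. The 4-methylphenyl and pyridin-3-yl groups cannot be told apart, with a 2.0-fold higher number from compound 1 to compound 4 (0.29 log units; within the scatter), so the four compounds now form two pairs, with the amino-bearing compound 2 and the hydroxy-bearing compound 3 at the low numbers and compound 1 and compound 4 at the high numbers. Nothing measured here explains this split between the pairs.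

Going by these compounds, with only four compounds, it remains open whether the hydrogen of the hydroxy group matters or its oxygen alone is enough, which a 4-methoxyphenyl group would help to separate. It is also unclear whether the amine in compound 2 can do the same job without the nitro group, as a 4-aminophenyl or 2-aminophenyl group would show, and how an unsubstituted phenyl group would compare with the methyl-bearing ring.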